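A few compounds are considered here, and "the series" means these few. Any claim that something is new, unique, unknown or untested is made for them only; others in the source may bear on it.

In an ADME assay on Vero cells (Chlorocebus sabaeus) for cytotoxicity, read by MTT assay (a lower number here means a stronger inhibitor, a higher number a weaker inhibitor), compound 1 (`C=CCOc1cc(OC)c(C(=O)/C=C/c2cccc(OC)c2)c(OCC=C)c1`) reads 142000 nM and compound 2 (`C=CCOc1cc(OC)c(C(=O)/C=C/c2ccc(OC)cc2)c(OCC=C)c1`) reads 99900 nM on the same scale. Among the measured compounds shown here, compound 2 therefore stands level with compound 1 within the scatter, and the series so far offers no separation.

The next compound is compound 3 (`C=CCOc1cc(OC)c(C(=O)/C=C/c2ccncc2)c(OCC=C)c1`). The change is pyridin-4-yl in place of 4-methoxyphenyl on a double-bonded chain carbon bound to a double-bonded chain carbon and amounts to pyridin-4-yl in place of 4-methoxyphenyl on a double-bonded chain carbon bound to a double-bonded chain carbon.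

For the measured compounds named here, only one measured step bears on this: a 1.4-fold lower number from compound 1 to compound 2 (0.15 log units; within the scatter) stays within the scatter. That step exchanges 3-methoxyphenyl for 4-methoxyphenyl at the same place, and both rings are of carbon only. Going by the values given here, no measured compound yet carries a ring with a hetero atom here, so the data give no direction for the new change. No step beyond the scatter is expected, but this rests on thin evidence, and the range is kept wide.

The expected change is a 1.0-fold higher number from compound 2 to compound 3 (0.00 log units; within the scatter) on this estimate. In this assay the estimate for compound 3 is 100000 nM with an expected range of 40000 nM to 250000 nM around it.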

Compound 3, half-maximal inhibitory concentration: 2800 nM
For compound 3 the middle estimate is 36-fold (1.55 log units) above the measured one, and the stated range ends above it.
By their numbers in this assay, from the lowest: compound 3; then compounds 2 and 1 (each within the scatter of the next).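

Working notes on the series: in this assay, the place on the double-bonded chain carbon bound to a double-bonded chain carbon now shows a clear response to the identity of the ring. Pyridin-4-yl in place of 4-methoxyphenyl gives a step beyond the scatter (a 36-fold lower number from compound 2 to compound 3 (1.55 log units; beyond the scatter)), and pyridin-4-yl in place of 3-methoxyphenyl gives another (a 51-fold lower number from compound 1 to compound 3 (1.71 log units; beyond the scatter)), whereas the exchange between the two methoxyphenyl groups stayed within it (a 1.4-fold lower number from compound 1 to compound 2 (0.15 log units; within the scatter)), so compound 3 stands apart from compound 1 and compound 2, which remain level with each other. No supporting measurement is available to account for this separation.

The change to compound 3 removes the methoxy group and places a nitrogen in the ring in a single exchange, so the two contributions cannot be told apart from these compounds; unsubstituted phenyl at the same place would bear directly on that question. Also open, on these data alone, is whether the step is specific to pyridin-4-yl or extends to other rings at this place, such as a phenyl ring carrying an amine.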